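The source may report more compounds than this note shows. Statements on the series, on what has been measured and on what is new or still open speak of the compounds shown alone.

Compound 2 `C[C@H](Nc1ccc(C#N)n(C)c1=O)c1cc2cc(Cl)c(OCc3ccccn3)cc2[nH]c1=O` stands second highest of the three numbers in a physicochemical assay for solubility (on this read-out higher numbers stand for higher solubility and lower numbers for lower solubility), where compound 2 gives 2500 nM; compound 1 `C[C@H](Nc1ccc(C#N)n(C)c1=O)c1cc2cc(Cl)c(O[C@H](C)c3ccccn3)cc2[nH]c1=O` gives 1600 nM and compound 3 `O=c1[nH]c2ccc(Cl)cc2cc1CNc1cccn(C2CC2)c1=O` gives 56000 nM. Within the data shown here, the only single-point step among the measured compounds is a 1.6-fold higher number from compound 1 to compound 2 (0.19 log units; within the scatter), and it touches the saturated chain carbon, not the ring on it. Compound 4 `C[C@H](Nc1ccc(C#N)n(C)c1=O)c1cc2cc(Cl)c(OCC3CC3)cc2[nH]c1=O` differs from compound 2 by cyclopropyl in place of pyridin-2-yl on a saturated chain carbon bound to an oxygen on an aromatic ring. Among the measured compounds shown here, no measured step covers a change of this ring, so the direction is open; a step of the size seen from compound 1 to compound 2 would stay within the scatter. For compound 4 the expected step is a 2.5-fold lower number from compound 2 to compound 4 (0.40 log units; beyond the scatter), taken as an estimate without a measured precedent. Compound 4 is therefore estimated at 1000 nM, within 300 nM to 3500 nM.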

Compound 4, solubility: 530 nM
Compound 4: middle estimate off by 1.9-fold (0.28 log units), on the high side, and the stated range covers the measured number.
By their numbers in this assay, from the lowest: compound 4; then compounds 1 and 2 (each within the scatter of the next); then compound 3.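

In this assay, changing the ring on the saturated chain carbon bound to an oxygen on an aromatic ring gives a step that can be read: cyclopropyl in place of pyridin-2-yl yields a 4.7-fold lower number from compound 2 to compound 4 (0.67 log units; beyond the scatter), larger than the earlier change on the chain carbon. Cyclopropylmethyl in place of 1-(pyridin-2-yl)ethyl on the oxygen yields a 3.0-fold lower number from compound 1 to compound 4 (0.48 log units; beyond the scatter), so the lower number holds against both pyridine-bearing compounds. No evidence on the cause of these steps is available.

Among these compounds, only this one ring exchange is covered here, so the reading extends no further than these compounds. Open, from the compounds shown here alone, is how a morpholine or a carboxylic acid at this place would compare.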